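From a Furan-2-yl Amide to a Methoxycarbonyl Amide

This account rests on a few compounds, and the source may have more. Where it says the series, first, only, none or still open, it means among the compounds named here.

The two measured compounds share one core. Compound 2 `COc1cc(/C=C/C(=O)c2cccc(NC(=O)c3ccco3)c2)ccc1O` carries a (furan-2-yl)carbonyl on the amide-type nitrogen, and in a functional assay on HUVEC cells (Homo sapiens) for inhibition (a higher number here means a weaker inhibitor, a lower number a stronger inhibitor), compound 2 gives 0.38 ug/mL. Compound 1 `COc1cc(/C=C/C(=O)c2cccc(NC(=O)c3c(Cl)cccc3Cl)c2)ccc1O` has 2,6-dichlorophenyl in the same place, and in this assay compound 1 gives 0.46 ug/mL. Among the measured compounds shown here, the only measured step is a 1.2-fold lower number from compound 1 to compound 2 (0.08 log units; within the scatter), so the two numbers sit within the scatter of each other and compound 2 stands alongside compound 1 rather than apart from it.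

Compound 3 `COC(=O)C(=O)Nc1cccc(C(=O)/C=C/c2ccc(O)c(OC)c2)c1` differs from compound 2 in one place: methoxycarbonyl in place of furan-2-yl on a carbonyl carbon. For the measured compounds named here, no measured step swaps an aromatic ring for a group without a ring, so the single recorded step bears on it only loosely: exchanging one ring for another kept both numbers within the scatter. The step from compound 2 to compound 3 is therefore expected to be modest, a 1.4-fold higher number from compound 2 to compound 3 (0.16 log units; within the scatter). The number for compound 3 is estimated near 0.55 ug/mL, within 0.2 ug/mL to 1.5 ug/mL.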

Compound 3, half-maximal inhibitory concentration: 1.5 ug/mL
Estimate against measurement, compound 3: 2.7-fold (0.44 log units) below; low and high end bracket the measured number.
By their numbers in this assay, from the lowest: compounds 2 and 1 (each within the scatter of the next); then compound 3.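

Up to this point, the carbonyl carbon had carried only rings, furan-2-yl and 2,6-dichlorophenyl, and their numbers lay within the scatter of each other. With ring-free methoxycarbonyl on that carbon, this assay gives a 3.9-fold higher number from compound 2 to compound 3 (0.60 log units; beyond the scatter) and a 3.3-fold higher number from compound 1 to compound 3 (0.51 log units; beyond the scatter) so this position is not indifferent to every change, and compound 3 is the weaker inhibitor against both ring-bearing compounds. Nothing shown here explains this weakening.

The three compounds cannot separate the loss of the ring from the arrival of methoxycarbonyl itself, since both happen in the same change. A cyclohexyl ring, a plain methyl group or a carboxylic acid on the same carbonyl carbon would help tell these two readings apart.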